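Lipophilicity of a dichloroaryl formamidine ether series

The compounds below may be only part of what the source reports. "The series", "measured", "known", "first", "only" and "open" are said of these compounds alone.

Measured compounds:
compound 1 `CCO/N=C/Nc1cc(Cl)c(SCC)c(Cl)c1`, 4.6
compound 2 `CCO/N=C/Nc1cc(Cl)c(O)c(Cl)c1`, 2.8
compound 3 `C=CCOc1c(Cl)cc(N/C=N/OCC)cc1Cl`, 4.3

In a physicochemical assay for lipophilicity, measured as octanol-water partition (on this read-out higher numbers stand for higher lipophilicity and lower numbers for lower lipophilicity), compound 1 stands highest of the three numbers. Its nearest neighbour is compound 3, which gives 4.3, and the step of a number 0.30 log units lower from compound 1 to compound 3 (within the scatter) lies within the scatter. Compound 2 sits furthest away, and the step of a number 1.80 log units lower from compound 1 to compound 2 (beyond the scatter) is large. Compound 4 `CC#CCOc1c(Cl)cc(N/C=N/OCC)cc1Cl` has not yet been measured in this assay. It differs from compound 1 in one place: (but-2-yn-1-yl)oxy in place of ethylsulfanyl on an aromatic carbon. Among the compounds with values here, the closest precedent is the step to compound 3, where allyloxy in place of ethylsulfanyl on the same aromatic carbon moved the number only within the scatter. The step of a number 1.50 log units higher from compound 2 to compound 3 (beyond the scatter) shows how far an unsubstituted hydroxy falls below such ethers, but compound 4 keeps an ether, so that step bears less directly. The (but-2-yn-1-yl)oxy group resembles allyloxy, so a step of about the size a number 0.30 log units lower from compound 1 to compound 4 (within the scatter) is expected, and compound 4 is estimated at 4.3, within 3.9 to 4.7.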

Compound 4, partition coefficient: 4
For compound 4 the middle estimate is 0.30 log units above the measured one, and the stated range covers the measured number.
By their numbers in this assay, from the lowest: compound 2; then compounds 4, 3 and 1 (each within the scatter of the next, the first and the last beyond it).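

In this assay, the (but-2-yn-1-yl)oxy group on this aromatic carbon, ortho to two chloro groups, gives the series a step from ethylsulfanyl that clears the scatter, with a number 0.60 log units lower from compound 1 to compound 4 (beyond the scatter), which the allyloxy ether had not done. The two ethers still cannot be told apart, since prop-1-yn-1-yl in place of vinyl gives a number 0.30 log units lower from compound 3 to compound 4 (within the scatter), so the position tolerates this change in the ether chain without a readable shift. The but-2-yn-1-yl ether also stands well clear of the free hydroxy, with a number 1.20 log units higher from compound 2 to compound 4 (beyond the scatter) and nothing given here accounts for any of these steps.

The compounds shown leave open where ethoxy, the plain oxygen counterpart of ethylsulfanyl, would fall. They also leave open how a longer saturated chain on the oxygen, or an amine at this position, would compare with compound 1.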